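Bromo in place of chloro: the step to compound 4

The source may report more compounds than this note shows. Statements on the series, on what has been measured and on what is new or still open speak of the compounds shown alone.

Measured so far in a functional assay on DU-145 cells (Homo sapiens) for inhibition, read by trypan blue exclusion, with a stated time of 96 h; on this read-out lower numbers stand for stronger inhibition of growth and higher numbers for weaker inhibition of growth:
compound 1 `O=C(/C(=C\c1ccc(Br)cc1)Sc1ccc(Br)cc1)c1ccc(Br)cc1`: 1000 nM
compound 2 `O=C(/C(=C\c1ccc(Br)c(O)c1)Sc1ccc(Br)cc1)c1ccc(Br)cc1`: 1000 nM
compound 3 `O=C(/C(=C\c1ccc(Cl)c([N+](=O)[O-])c1)Sc1ccc(Br)cc1)c1ccc(Br)cc1`: 10000 nM

Of the three, compound 3 gives the highest number, clearly apart from the other two. Compound 4 `O=C(/C(=C\c1ccc(Br)c([N+](=O)[O-])c1)Sc1ccc(Br)cc1)c1ccc(Br)cc1` is still unmeasured and departs from compound 3 in one place: bromo in place of chloro on an aromatic carbon. The nitro group stays. For the measured compounds named here, no measured step exchanges one halogen for another. Going by the values given here, the only single-place step available, hydroxy in place of hydrogen on an aromatic carbon, is no change at the digits printed from compound 1 to compound 2 (within the scatter) and it concerns a different change, so it bears only loosely on this one. Compound 1 (1000 nM) carries bromo without the nitro group, which allows a slight lean towards lower numbers. No step beyond the scatter is expected, and the estimated step is a 1.4-fold lower number from compound 3 to compound 4 (0.15 log units; within the scatter) in this assay. For compound 4 the expected value is 7000 nM, with an estimated range from 2500 nM to 15000 nM.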

Compound 4, concentration for 50% growth inhibition: 1000 nM
Beside the measured number, compound 4's estimate is 7.0-fold (0.85 log units) above it; measured number below the stated range.
By their numbers in this assay, from the lowest: compounds 1, 2 and 4 (each within the scatter of the next); then compound 3.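

Bromo in place of chloro on this aromatic carbon, ortho to a nitro group, gives a 10-fold lower number from compound 3 to compound 4 (1.00 log units; beyond the scatter) in this assay, so with the nitro group held constant, the identity of the halogen matters at this position. With bromo kept at the same carbon, nitro in place of hydrogen gives no change at the digits printed from compound 1 to compound 4 (within the scatter) and nitro in place of hydroxy gives no change at the digits printed from compound 2 to compound 4 (within the scatter). Among these bromo compounds, the nitro group therefore leaves the number unmoved, and only compound 3, with chloro, stands apart.

From the compounds shown here alone, whether chloro gives the same high number without the nitro group remains open, as does how a methyl group or an amine would compare with bromo on this carbon. No measurement at hand accounts for the halogen step.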